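Saturating the terminal alkene of a polyacetylenic acid

The source may hold more compounds than are shown below. What is called first, only, known or untested is meant among the compounds shown, and "the series" means these compounds.

The study gives measurements in a functional assay on NCI-H460 cells (Homo sapiens) for cytotoxicity, read by sulforhodamine B assay, with a stated time of 3 days (a higher number here means a weaker inhibitor, a lower number a stronger inhibitor), for two compounds and leaves a third to be measured. Compound 1, `C=C1C[C@]2(C(=O)O)C[C@H]1CC[C@H]2[C@]1(C)CCC[C@@](C)(C(=O)OC)[C@H]1C(=O)O`, gives in this assay only a limit of the assay, > 10000 nM, and no number. Compound 2, `C=CCCC#CC#CC#CCCCCCCCC(=O)O`, gives in this assay a value of 10000 nM. Within the data shown here, compound 2 therefore supplies the only number in hand, since the other reading is a limit (the limit of > 10000 nM in this assay, at which 1 of the 2 values shown sits), so there is no measured step against which its standing could be judged.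

Compound 3, `CCCCC#CC#CC#CCCCCCCCC(=O)O`, remains unmeasured. It differs from compound 2 by ethyl in place of vinyl on a saturated chain carbon, two bonds along the chain from a triple-bonded carbon. Among the measured compounds shown here, no measured pair shows a change of this kind, and the account can only expect a step in this assay that stays within the usual scatter, in neither direction, so that the expected step from compound 2 to compound 3 is no change at the digits printed from compound 2 to compound 3 (within the scatter). On that basis compound 3 is estimated to give 10000 nM in this assay, with a range from 4000 nM to 25000 nM.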

Compound 3, half-maximal inhibitory concentration: 10000 nM
Beside the measured number, compound 3's estimate shows no gap at the digits printed; the range from low to high includes it.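

Among these compounds, the change from vinyl to ethyl gives no change at the digits printed from compound 2 to compound 3 (within the scatter) in this assay, and this is the first measured step at this place, on a saturated chain carbon, two bonds along the chain from a triple-bonded carbon. Within this one pair, the double bond that leaves with the vinyl group is not needed to hold the reading, and the triple-bonded part of the chain and the acid are the same in both compounds. Compound 1 gives only a limit of the assay, > 10000 nM and no number, so it adds no comparison, and the step from compound 2 to compound 3 remains the only one that can be read: the limit of > 10000 nM in this assay, at which 1 of the 3 values shown sits.

The compounds shown leave open whether a hydroxyl, an amine or a phenyl group at this place would move the reading in this assay beyond the scatter. They also leave open whether an amide in place of the carboxylic acid of compound 3, or a shorter chain, would change it.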